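Thiazolylmethyl ether in place of a trifluoroethyl ether

The source may report more compounds than this note shows. Statements on the series, on what has been measured and on what is new or still open speak of the compounds shown alone.

Compound 1 `O=c1[nH]cc(-c2cc(-c3cc(Cl)cc(OCc4scnc4C(F)(F)F)c3)c(=O)n(-c3cccnc3)c2)c(=O)[nH]1` in an ADME assay on Vero C1008 cells (Chlorocebus sabaeus) for cytotoxicity, read by MTT assay, with a stated time of 72 h (a higher number here means that more compound is tolerated, a lower number that less compound is tolerated), gives > 100000 nM, which is a limit of the assay rather than a number. Compound 2 `Cn1cc(-c2cc(-c3cc(Cl)cc(OCC4CC4)c3)c(=O)n(-c3cccnc3)c2)c(=O)[nH]c1=O` gives 82000 nM. Compound 3 `Cn1cc(-c2cc(-c3cc(Cl)cc(OCCC(F)(F)F)c3)c(=O)n(-c3cccnc3)c2)c(=O)[nH]c1=O` gives > 100000 nM, again a limit of the assay and not a number.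

Compound 3 therefore stands at the top of what this assay can report, a position it shares with one other value (the limit of > 100000 nM in this assay, at which 2 of the 3 values shown sit). The change to compound 4 `Cn1cc(-c2cc(-c3cc(Cl)cc(OCc4scnc4C(F)(F)F)c3)c(=O)n(-c3cccnc3)c2)c(=O)[nH]c1=O` is a group of 9 heavy atoms (4 carbon, 1 nitrogen, 3 fluorine, 1 sulfur; one five-membered aromatic ring with 2 hetero atoms) in place of a group of 5 heavy atoms (2 carbon, 3 fluorine; no ring), on a saturated chain carbon bound to an oxygen on an aromatic ring. For the measured compounds named here, only one measured step touches this place on the molecule, an at least 1.2-fold higher number from compound 2 to compound 3 (0.08 log units; that floor lies within the scatter), and it lies within the scatter. Compound 1 also carries the entering group, and compound 1 sits at the limit > 100000 nM. No step beyond the scatter is expected in this assay in either direction. Compound 4 is expected to give 100000 nM, with a range from 50000 nM to 200000 nM. The step of a number no higher from compound 3 to compound 4 (the limit leaves the size open) that this estimate implies is expected to stay within the scatter, most likely with the assay again reporting only a limit.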

Compound 4, half-maximal cytotoxic concentration: > 100000 nM
Compound 4: no number, only a limit; the forecaster's own chance of this, stated with the estimate: 70%; the middle value sits exactly at the limit.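

In this assay compound 4 gives > 100000 nM, a limit of the assay and not a number, so the five-membered aromatic ring group, seen before only on compound 1, now also appears at the top of the assay's range with a methyl on the aromatic nitrogen. For the compounds shown here, the one readable step is an at least 1.2-fold higher number from compound 2 to compound 4 (0.08 log units; that floor lies within the scatter), while the steps to compound 4 from compound 3 and from compound 1 cannot be read, with limits at both ends. The assay's ceiling now holds most of the series: the limit of > 100000 nM in this assay, at which 3 of the 4 values shown sit.

From the compounds shown here alone, how far the compounds at that ceiling lie from one another stays unknown, so they cannot be ranked. Going by these compounds, whether an amine or a carboxylic acid on this chain would bring the number down also remains open.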